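Pyrazole carbamate series: cyano on the pyrazole, two cores

The compounds below may be only part of what the source reports. "The series", "measured", "known", "first", "only" and "open" are said of these compounds alone.

Compound 1 `O=C(N1CCCN(Cc2ccc(OCc3ccccc3)cc2)CC1)n1cccn1` and compound 2 `N#Cc1cnn(C(=O)N2CCCN(Cc3ccc(OCc4ccccc4)cc3)CC2)c1` share one core. In an assay on membranes from brain for binding affinity to Monoglyceride lipase (Mus musculus), read by fluorescence, with stated times of 1 h and 30 min (on this read-out higher numbers stand for weaker inhibition and lower numbers for stronger inhibition), compound 1 gives 10000 nM, and compound 2 gives 10000 nM. The difference between them is cyano in place of hydrogen on an aromatic carbon, and the step it made was no change at the digits printed from compound 1 to compound 2 (within the scatter).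

Compound 3 `CN(CCN(C)C(=O)n1cccn1)Cc1cccc(OCc2ccccc2)c1` is built on a different core; the difference between the two cores is not broken down here. In this assay compound 3 gives 4600 nM, which is the lowest of the three numbers, with both other compounds standing beyond the scatter above it.

Compound 4 `CN(CCN(C)C(=O)n1cc(C#N)cn1)Cc1cccc(OCc2ccccc2)c1` is not yet measured. It differs from compound 3 by cyano in place of hydrogen on an aromatic carbon, the same change as that between compound 1 and compound 2, at the same place of the same five-membered ring. For compound 4 the step in this assay is expected to be a 1.0-fold lower number from compound 3 to compound 4 (0.01 log units; within the scatter), because no change at the digits printed from compound 1 to compound 2 (within the scatter) on the other core. That rests on a single pair, so the range is kept wide. The estimate for compound 4 is 4500 nM, with a range from 1500 nM to 12000 nM.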

Compound 4, half-maximal inhibitory concentration: 590 nM
The estimate for compound 4 lay 7.6-fold (0.88 log units) above the measured number; the measured number lies below the stated range.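

In this assay, the change from 1H-pyrazol-1-yl to 4-cyano-1H-pyrazol-1-yl gives a 7.8-fold lower number from compound 3 to compound 4 (0.89 log units; beyond the scatter) on one core and no change at the digits printed from compound 1 to compound 2 (within the scatter) on the other. The result on one core therefore does not predict the result on the other, and the two steps differ: the same change on two cores in this assay, no change at the digits printed (within the scatter) from compound 1 to compound 2 and a 7.8-fold lower number (0.89 log units; beyond the scatter) from compound 3 to compound 4, 7.8-fold (0.89 log units) apart, beyond the scatter of two such steps. This shows that the size of the cyano step depends on the core for these two pairs, but with one pair per core it does not show which part of the core matters or how the change would behave on a third core.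

Going by these compounds, the two cores differ in more than one place, so it remains open which of those differences sets the size of the step. Also open, on these data alone, is whether a chlorine, a methyl or a carboxylic acid in place of cyano on the same aromatic carbon would give a comparable step on the core of compound 3.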